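The compounds below may be only part of what the source reports. "The series", "measured", "known", "first", "only" and "open" are said of these compounds alone.

In a functional assay on HeLa cells (Homo sapiens), with a stated time of 5 days (a lower number here means a stronger inhibitor, a higher number a weaker inhibitor), compound 1 `O=Cc1cn(-c2ccc(O)cc2)nc1-c1cccc(O)c1` gives 37000 nM and compound 2 `O=Cc1cn(-c2ccc(O)cc2)nc1-c1ccc(O)c(O)c1` gives 39000 nM; the two numbers lie within the usual scatter of each other, so compound 1 stands alongside compound 2 rather than apart from it. Compound 3 `O=Cc1cn(-c2ccc(O)cc2)nc1-c1ccc(O)cc1` differs from compound 1 in one place: 4-hydroxyphenyl in place of 3-hydroxyphenyl on an aromatic carbon. For the measured compounds named here, only one measured step bears on this, a 1.1-fold higher number from compound 1 to compound 2 (0.02 log units; within the scatter), which adds a hydroxy on an aromatic carbon and shows nothing beyond the scatter. Compound 3 is therefore expected to stay within the scatter of compound 1, and is estimated at 37000 nM, between 15000 nM and 90000 nM. The expected step is no change at the digits printed from compound 1 to compound 3 (within the scatter).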

Compound 3, half-maximal inhibitory concentration: 37000 nM
Compound 3: the middle estimate sits on the measured number at the digits printed; the measured number falls inside the stated range.
By their numbers in this assay, from the lowest: compounds 1, 3 and 2 (each within the scatter of the next).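

In this assay, 4-hydroxyphenyl in place of 3-hydroxyphenyl on this aromatic carbon gives no change at the digits printed from compound 1 to compound 3 (within the scatter), so the place of the hydroxy on this ring, and not only its addition, leaves the number within the scatter. Hydrogen in place of hydroxy gives a 1.1-fold lower number from compound 2 to compound 3 (0.02 log units; within the scatter), which means that compounds 1, 2 and 3 cannot be told apart at this position. No available evidence accounts for this result. The compounds shown leave open whether another group on this ring, such as an amine or a carboxylic acid, would move the number beyond the scatter.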